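A Third Hydroxyphenyl Rearranged on the Shared Core

A few compounds are considered here, and "the series" means these few. Any claim that something is new, unique, unknown or untested is made for them only; others in the source may bear on it.

Compound 1 `Oc1ccc(-c2cc(-c3ccccc3O)cc(-c3cccc(O)c3)n2)cc1` gives 5370 nM in a functional assay on DU-145 cells (Homo sapiens) for cytotoxicity, read by CCK-8 assay, with a stated time of 4 days (a higher number here means a weaker inhibitor, a lower number a stronger inhibitor), the highest of the two numbers shown, the nearest being compound 3 `Oc1ccc(-c2cc(-c3cccc(O)c3)cc(-c3cccc(O)c3)n2)cc1` with 1940 nM. Compound 2 `Oc1cccc(-c2cc(-c3ccccc3O)cc(-c3cccc(O)c3)n2)c1` reaches only the limit > 50000 nM in this assay. Compound 4 `Oc1ccc(-c2cc(-c3ccccc3O)cc(-c3ccccc3O)n2)cc1` differs from compound 1 by 2-hydroxyphenyl in place of 3-hydroxyphenyl on an aromatic carbon. Among the compounds with values here, two measured steps bear on this change. an at least 9.3-fold higher number from compound 1 to compound 2 (0.96 log units; beyond the scatter), while a 2.8-fold lower number from compound 1 to compound 3 (0.44 log units; beyond the scatter); read in reverse, that second step suggests that a 2-hydroxyphenyl in place of a 3-hydroxyphenyl raises the number. A modest rise beyond the scatter is therefore expected, a 2.4-fold higher number from compound 1 to compound 4 (0.38 log units; beyond the scatter). For compound 4 the estimated value in this assay is 13000 nM, with a range from 5000 nM to 40000 nM.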

Compound 4, half-maximal inhibitory concentration: 360 nM
For compound 4 the middle estimate is 36-fold (1.56 log units) above the measured one, and the stated range ends above it.
By their numbers in this assay, from the lowest: compound 4; then compound 3; then compound 1. At a limit, above all of these: compound 2.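

The same swap of hydroxyphenyl groups does not act the same way everywhere on the shared core: on the aromatic carbon next to the ring nitrogen, 2-hydroxyphenyl in place of 3-hydroxyphenyl gives a 15-fold lower number from compound 1 to compound 4 (1.17 log units; beyond the scatter) in this assay. At the other place, the reverse swap also lowered the number, with a 2.8-fold lower number from compound 1 to compound 3 (0.44 log units; beyond the scatter), so the effect of the hydroxyl's placement depends on the site. Nothing shown here accounts for this reversal. Still open, going by these compounds, is how a methoxy or an amino group in place of that hydroxyl would read in this assay.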